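From Fluoromethyl to Methoxycarbonyl on the Shared Core

The source may report more compounds than this note shows. Statements on the series, on what has been measured and on what is new or still open speak of the compounds shown alone.

In an ADME assay on HEp-2 cells (Homo sapiens) for cytotoxicity (a lower number here means that less compound is tolerated, a higher number that more compound is tolerated), compound 1 `CC(C)CCn1c(Cn2c(=O)n(C(C)C)c3ccccc32)nc2cc(CN)ccc21` gives 3920 nM and compound 2 `CC(C)CCn1c(Cn2c(=O)n(C(C)C)c3ccccc32)nc2cc(CN(C)C)ccc21` gives 5650 nM, which amounts to a 1.4-fold higher number from compound 1 to compound 2 (0.16 log units; within the scatter). Compound 3 `CC(C)CCn1c(Cn2c(=O)n(C(C)C)c3ccccc32)nc2cc(CF)ccc21` stands highest of the three at 37300 nM. The data show a 9.5-fold higher number from compound 1 to compound 3 (0.98 log units; beyond the scatter) and a 6.6-fold higher number from compound 2 to compound 3 (0.82 log units; beyond the scatter).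

Compound 4 `COC(=O)c1ccc2c(c1)nc(Cn1c(=O)n(C(C)C)c3ccccc31)n2CCC(C)C` departs from compound 3 through one change: methoxycarbonyl in place of fluoromethyl on an aromatic carbon. All three measured steps exchange groups on a saturated chain carbon, so none of them tests methoxycarbonyl directly. The two modest steps set amino and dimethylamino apart from fluoro, and neither group is present in compound 4. Compound 3, at 37300 nM, is therefore the closest guide, and no step beyond the scatter is expected, though the direction is uncertain. The expected change is a 1.2-fold lower number from compound 3 to compound 4 (0.09 log units; within the scatter). Compound 4 is estimated at 30000 nM. The expected range for compound 4 runs from 13000 nM to 70000 nM.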

Compound 4, half-maximal cytotoxic concentration: 33700 nM
Compound 4: middle estimate off by 1.1-fold (0.05 log units), on the low side, and the stated range covers the measured number.
By their numbers in this assay, from the lowest: compounds 1 and 2 (each within the scatter of the next); then compounds 4 and 3 (each within the scatter of the next).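

In this assay the result a 1.1-fold lower number from compound 3 to compound 4 (0.04 log units; within the scatter) shows that methoxycarbonyl and fluoromethyl on this aromatic carbon cannot be told apart, so the high number of compound 3 is not particular to fluoromethyl. The separation from the nitrogen-bearing groups also recurs, with a 6.0-fold higher number from compound 2 to compound 4 (0.78 log units; beyond the scatter) and with an 8.6-fold higher number from compound 1 to compound 4 (0.93 log units; beyond the scatter) in this series, so among the four compounds both groups without nitrogen at this position sit apart from (dimethylamino)methyl and aminomethyl. No measurement on hand accounts for this separation.

On these data alone, whether a carboxylic acid or a primary amide at this position would stay with compound 3 and compound 4 or fall with compound 1 and compound 2 remains open. So does whether a nitrile or a hydroxymethyl group would read like methoxycarbonyl on the shared core.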